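Cytotoxicity notes on compounds 1 to 4

The source may report more compounds than this note shows. Statements on the series, on what has been measured and on what is new or still open speak of the compounds shown alone.

Compound 1 `CCCCNc1cc(Oc2c(OC)cc3cc(C#N)ccc3c2OC)nc(Nc2ccc(C#N)cc2)n1` in an ADME assay on MT4 cells (Homo sapiens) for cytotoxicity, read by MTT assay, with a stated time of 5 days (on this read-out higher numbers stand for lower toxicity in this test and lower numbers for higher toxicity in this test), gives > 125000 nM, a limit of the assay.
Compound 2 `COc1cc2cc(C#N)ccc2c(OC)c1Oc1cc(NCCC2=CCCCC2)nc(Nc2ccc(C#N)cc2)n1` in this assay gives > 125000 nM, again a limit.
Compound 3 `COc1cc2cc(C#N)ccc2c(OC)c1Oc1cc(NCC2CCOCC2)nc(Nc2ccc(C#N)cc2)n1` in this assay gives > 125000 nM, also a limit.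

Compound 1 therefore stands at the limit, as do the other two; all values sit at the limit of > 125000 nM in this assay, at which 3 of the 3 values shown sit. Compound 4 `COc1cc2cc(C#N)ccc2c(OC)c1Oc1cc(NCC2CCOC2)nc(Nc2ccc(C#N)cc2)n1` differs from compound 1 by oxolan-3-yl in place of propyl on a saturated chain carbon bound to a nitrogen on an aromatic ring. The two steps that bear on this change are a step that the two limits leave unreadable from compound 1 to compound 2 and a step that the two limits leave unreadable from compound 1 to compound 3; both are unreadable because the values sit at the limit of > 125000 nM in this assay, at which 3 of the 3 values shown sit. Nothing here points to a readable step in this assay in either direction. Compound 4 is expected to give 200000 nM (range 100000 nM to 500000 nM), most likely again reported as a limit, with the expected step that the limit leaves unreadable from compound 1 to compound 4.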

Compound 4, half-maximal cytotoxic concentration: > 125000 nM
Compound 4: no number, only a limit; the forecaster's own chance of this, stated with the estimate: 85%; the middle value is on the limit's open side.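

In this assay compound 4 gives > 125000 nM, a limit. For the compounds shown here, no step from compound 1, compound 2 or compound 3 to compound 4 can be read: the limit of > 125000 nM in this assay, at which 4 of the 4 values shown sit. The compounds shown leave open whether any of these amine side chains on the shared core would give a numerical half-maximal cytotoxic concentration in this assay.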